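Ring replaced by open chain on the shared core

This account rests on a few compounds, and the source may have more. Where it says the series, first, only, none or still open, it means among the compounds named here.

Compound 2 `c1cnc(-c2ccccc2NCC2=NCCN2)nc1` stands at the higher end of the two numbers in an in vitro assay on cells (Fibroblast) for binding affinity to Alpha-1A adrenergic receptor (Homo sapiens) (on this read-out lower numbers stand for stronger inhibition and higher numbers for weaker inhibition), where compound 2 gives 191 nM. Going by the values given here, its only neighbour, compound 1 `c1ccc(-c2ccccc2NCC2=NCCN2)nc1`, gives 81.3 nM in this assay; the step of a 2.3-fold higher number from compound 1 to compound 2 (0.37 log units; beyond the scatter) is the single measured step. Compound 3 `CO/N=C/c1ccccc1NCC1=NCCN1` is the next point: a group of 4 heavy atoms (2 carbon, 1 nitrogen, 1 oxygen; no ring) in place of a group of 6 heavy atoms (4 carbon, 2 nitrogen; one six-membered aromatic ring with 2 hetero atoms), on an aromatic carbon. The measured step exchanges one six-membered aromatic ring for another on the same aromatic carbon and says little about removing the ring altogether; it bears on the change only in showing that this position tolerates modest variation without large loss. Among the compounds with values here, no measured step covers an open-chain group here, so the direction of the change is open, and the uncertainty is wide. Compound 3 is expected to fall near compound 2, with a step of about a 1.3-fold higher number from compound 2 to compound 3 (0.12 log units; within the scatter) in this assay, which lies within the scatter. The estimate for compound 3 is 250 nM, with a range from 60 nM to 1000 nM.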

Compound 3, half-maximal inhibitory concentration: 282 nM
Beside the measured number, compound 3's estimate is 1.1-fold (0.05 log units) below it, and the stated range covers the measured number.
By their numbers in this assay, from the lowest: compound 1; then compounds 2 and 3 (each within the scatter of the next).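

In this assay, the aromatic ring on this aromatic carbon can give way to an open chain with no ring: replacing pyrimidin-2-yl gives a 1.5-fold higher number from compound 2 to compound 3 (0.17 log units; within the scatter), so the two compounds cannot be separated on this read-out. Replacing pyridin-2-yl with the same open group gives a 3.5-fold higher number from compound 1 to compound 3 (0.54 log units; beyond the scatter), a modest step beyond the scatter, which shows that a ring is not required here for a number of this order, although compound 1 still holds the lowest number of the series. Nothing on hand explains either step.

From the compounds shown here alone, with a single open-chain group, it remains open whether the step from the pyridin-2-yl compound reflects loss of the ring or this particular group with its double bond outside aromatic rings. A phenyl ring, an amine, a carboxylic acid or a longer chain on the same aromatic carbon would show how far this tolerance extends and whether any open group can match compound 1.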